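Changing the Aryl Group on the Amine Nitrogen Again

The source may report more compounds than this note shows. Statements on the series, on what has been measured and on what is new or still open speak of the compounds shown alone.

Of the compounds shown here, two that share one core have been measured in a functional assay on BT-549 cells (Homo sapiens) for cytotoxicity, read by sulforhodamine B assay, with a stated time of 72 h; on this read-out higher numbers stand for weaker inhibition and lower numbers for stronger inhibition. Compound 1 `CCS(=O)(=O)Nc1cc(-c2ccc3ncnc(Nc4ccc(OC)c(OC)c4)c3c2)cnc1OC` gives 2590 nM in this assay. Compound 2 `CCS(=O)(=O)Nc1cc(-c2ccc3ncnc(Nc4ccc(F)c(C(=O)OC)c4)c3c2)cnc1OC` gives 2740 nM in this assay. Of these two numbers compound 2 carries the one at the top, yet compound 1 sits within the scatter of it, so the two cannot be told apart. For the measured compounds named here, the single measured step, a 1.1-fold higher number from compound 1 to compound 2 (0.02 log units; within the scatter), exchanged the aromatic group carried on the nitrogen and left the read-out essentially unchanged. Compound 3 `CCS(=O)(=O)Nc1cc(-c2ccc3ncnc(Nc4ccc(C(=O)OC)c(OC)c4)c3c2)cnc1OC` has not yet been measured; it arises from compound 2 by the change (3-methoxy-4-(methoxycarbonyl)phenyl in place of 4-fluoro-3-(methoxycarbonyl)phenyl on a nitrogen on an aromatic ring). Going by the values given here, this touches the same place as the one measured step, which stayed within the scatter, and no other information is available. A step of about a 1.0-fold lower number from compound 2 to compound 3 (0.01 log units; within the scatter) is therefore expected, with no change beyond the scatter. Compound 3 is estimated at 2700 nM, within a range from 1100 nM to 6500 nM.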

Compound 3, half-maximal inhibitory concentration: 3760 nM
Estimate against measurement, compound 3: 1.4-fold (0.14 log units) below, and the stated range covers the measured number.
By their numbers in this assay, from the lowest: compounds 1, 2 and 3 (each within the scatter of the next).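

In this assay, a second exchange of the aromatic group on the nitrogen also stays small, at a 1.4-fold higher number from compound 2 to compound 3 (0.14 log units; within the scatter). The narrowest comparison available, methoxycarbonyl in place of methoxy on an aromatic carbon, gives a 1.5-fold higher number from compound 1 to compound 3 (0.16 log units; within the scatter), so even this single-group exchange cannot be told apart from repeat-measurement scatter. Across compound 1, compound 2 and compound 3, the three aromatic groups on this nitrogen therefore give numbers that cannot be separated, which extends the flat picture from one exchange to all three pairs.

Going by these compounds, whether an aromatic group carrying an amine or a carboxylic acid, or a longer chain on this nitrogen, would move the number beyond the scatter remains open. No measurement available here bears on why these three groups read alike.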